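Growth Inhibition in DU-145 Cells: From Compound 1 to Compound 3

The source may report more compounds than this note shows. Statements on the series, on what has been measured and on what is new or still open speak of the compounds shown alone.

Compound 1 `COc1ccc(/C=C(\C(=O)c2ccc(Br)cc2)S(=O)(=O)c2ccc(Br)cc2)c(F)c1` gives 10000 nM
Compound 2 `COc1ccc(C(=O)/C(=C\c2ccc(Cl)cc2)S(=O)(=O)c2ccc(Cl)cc2)cc1` gives 4000 nM

In a functional assay on DU-145 cells (Homo sapiens) for inhibition, read by trypan blue exclusion, with a stated time of 96 h (on this read-out higher numbers stand for weaker inhibition of growth and lower numbers for stronger inhibition of growth), compound 1 gives the higher of the two numbers at 10000 nM and compound 2 the lower at 4000 nM with a gap beyond the scatter. Among the measured compounds shown here, these two compounds differ in more than one place, so no single-change step is available as a guide. The change leading to compound 3 `O=C(/C(=C\c1ccc(F)cc1)S(=O)(=O)c1ccc(Br)cc1)c1ccc(Br)cc1` is 4-fluorophenyl in place of 2-fluoro-4-methoxyphenyl on a double-bonded chain carbon bound to a double-bonded chain carbon and it leaves the rest of compound 1 untouched. For the measured compounds named here, with no measured step for this exchange, a modest fall in this assay is expected, one that may not clear the scatter, and the only support is compound 2 at 4000 nM as the lower number so far. The expected size is a 2.0-fold lower number from compound 1 to compound 3 (0.30 log units; within the scatter) as an estimate only. Compound 3 is estimated at 5000 nM (expected range 1500 nM to 15000 nM).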

Compound 3, concentration for 50% growth inhibition: 4000 nM
Compound 3: the middle estimate sits 1.3-fold (0.10 log units) above what was measured; the measured number falls inside the stated range.
By their numbers in this assay, from the lowest: compounds 2 and 3 (each within the scatter of the next); then compound 1.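

In this assay, among the compounds shown here, the exchange of 2-fluoro-4-methoxyphenyl for 4-fluorophenyl on a double-bonded chain carbon bound to a double-bonded chain carbon gives a 2.5-fold lower number from compound 1 to compound 3 (0.40 log units; beyond the scatter) and provides the first single-change reading. It shows that the number responds to this position while the rest of compound 1 stays untouched, and that the 2-fluoro-4-methoxyphenyl group is not required for the growth inhibition seen here. No measurement at hand accounts for the step.

The compounds shown leave open how much of the step belongs to the loss of the methoxy group and how much to the different place of the fluorine. They also leave open what a phenyl carrying an amine or a carboxylic acid would give at this position.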